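The source may report more compounds than this note shows. Statements on the series, on what has been measured and on what is new or still open speak of the compounds shown alone.

The compounds here share a urea core carrying a benzyl arm, and all three measured so far were tested in an assay on microsomes from intestine for inhibition of acyl-CoA:cholesterol acyltransferase (Oryctolagus cuniculus); on this read-out lower numbers stand for stronger inhibition and higher numbers for weaker inhibition. Compound 1, `CN(C)c1ccc(CN(Cc2cccc(-c3cc[nH]n3)c2)C(=O)Nc2c(F)cc(F)cc2F)cc1`, gives 12 nM in this assay. Compound 2, `Cc1cc(C)c(NC(=O)N(Cc2ccc(-c3cccs3)cc2)C2CCCCCC2)c(C)c1`, gives 22 nM in this assay. Compound 3, `O=C(Nc1c(F)cc(F)cc1F)N(Cc1ccc(-n2cccc2)cc1)C1CCCCCC1`, gives 27 nM in this assay. The number for compound 2 sits between the other two: its gap to compound 3 and its gap to compound 1 both fall within the usual scatter of repeated measurements, so the three cannot be ranked on these values.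

The next compound, compound 4, is `Cc1cc(C)c(NC(=O)N(Cc2ccc(-n3ccnn3)cc2)C2CCCCCC2)c(C)c1`. It differs from compound 2 at one spot:

1H-1,2,3-triazol-1-yl in place of thiophen-2-yl on an aromatic carbon

Nothing measured here isolates this change, and compound 3 carries a different five-membered ring on its benzyl arm together with a different aryl urea, so it offers only a loose reference. The step from compound 2 to compound 4 is estimated as a 1.8-fold higher number from compound 2 to compound 4 (0.26 log units; within the scatter), a modest drift toward a higher number that may not clear the scatter. Compound 4 is expected to give about 40 nM in this assay, within a range from 12 nM to 130 nM.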

Compound 4, half-maximal inhibitory concentration: 42 nM
Compound 4: the middle estimate sits 1.1-fold (0.02 log units) below what was measured, and the stated range covers the measured number.
By their numbers in this assay, from the lowest: compounds 1, 2, 3 and 4 (each within the scatter of the next, the first and the last beyond it).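

For the compounds shown here, this is the first pair here that differs in one place only, so the ring at this position can be read on its own: in this assay, putting 1H-1,2,3-triazol-1-yl in place of thiophen-2-yl gives a 1.9-fold higher number from compound 2 to compound 4 (0.28 log units; within the scatter), and the shared core stays the same. A ring with 3 hydrogen-bond acceptors and a ring with 1 hydrogen-bond acceptor therefore cannot be told apart at this position on this read-out. No other measurement at hand bears on this result.

Open, on these data alone, is whether a carboxylic acid or an amine, rather than a five-membered aromatic ring, would be accepted at this position. Also open, as far as these compounds go, is whether the same swap would read alike on the core of compound 3, with its different aryl urea.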